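The source may report more compounds than this note shows. Statements on the series, on what has been measured and on what is new or still open speak of the compounds shown alone.

In a toxicity assay on RAW264.7 cells (Mus musculus) for cytotoxicity, read by MTT assay, with a stated time of 24 h (on this read-out higher numbers stand for lower toxicity in this test and lower numbers for higher toxicity in this test), compound 1 `CCCCNC(=S)NCc1ccccc1` gives 177000 nM. Compound 2 `COc1cc(NC(=S)NC#N)cc(OC)c1OC` reaches only a limit of this assay, reported as >= 200000 nM. Compound 3 `CC(C)NC(=S)NCc1ccccc1` likewise stops at a limit of this assay, >= 200000 nM. On the numbers shown, compound 3 therefore sits at the upper edge of what this assay reports, with no number of its own, a position it shares with compound 2, while compound 1 alone carries a measured number. Within the data shown here, the single measured step that bears on the present change, an at least 1.1-fold higher number from compound 1 to compound 3 (0.05 log units; that floor lies within the scatter), alters a chain on the same core and is covered by the scatter. Compound 4 `CCN(CC)C(=S)NCc1ccccc1` differs from compound 3 by diethylamino in place of isopropylamino on a thiocarbonyl carbon. Among the measured compounds shown here, no measured step touches the substituent on the thiocarbonyl carbon, so the guide is weak. For the measured compounds named here, compound 4 is nonetheless expected to stay at the limit as well because the limit of >= 200000 nM in this assay, at which 2 of the 3 values shown sit, and the one measured step stayed flat. The estimated step of a number no higher from compound 3 to compound 4 (the limit leaves the size open) is expected to lie within the scatter. The estimate for compound 4 is 200000 nM, expected between 90000 nM and 450000 nM, with a fair chance that this assay again reports only a limit.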

Compound 4, half-maximal cytotoxic concentration: >= 200000 nM
Compound 4 was reported as a limit; the forecaster's own chance of this, stated with the estimate: 60%; the middle value lies on the limit itself.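

In this assay, the place on the thiocarbonyl carbon now also holds diethylamino, which carries no hydrogen-bond donor, and compound 4 again gives only a limit, as compound 3 does, so the step between these two cannot be read. The comparison with butylamino gives an at least 1.1-fold higher number from compound 1 to compound 4 (0.05 log units; that floor lies within the scatter), and this is only a floor, so the true size of the step stays hidden. The limit is now the usual result in this small set, with compound 1 the one exception that carries a measured number: the limit of >= 200000 nM in this assay, at which 3 of the 4 values shown sit.

The compounds shown leave open how much room lies beyond the limit for compound 3 and compound 4. They also leave open whether a carboxylic acid or an octylamino chain on the thiocarbonyl carbon would give a measured number in this assay.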